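The source may hold more compounds than are shown below. What is called first, only, known or untested is meant among the compounds shown, and "the series" means these compounds.

Measured in a functional assay on PC-9 cells (Homo sapiens) for inhibition, read by MTT assay, with a stated time of 72 h; a lower number here means a stronger inhibitor, a higher number a weaker inhibitor:
compound 1 `Cc1cc(Nc2cc(-c3ccccc3)[nH]n2)n2nc(SCC3CCCCC3)nc2n1`: > 50000 nM (a limit of the assay, not a number)
compound 2 `Cc1cc(Nc2cc(-c3ccccc3)[nH]n2)n2nc(SCC(=O)c3ccccc3)nc2n1`: 4450 nM
compound 3 `Cc1cc(Nc2cc(-c3ccccc3)[nH]n2)n2nc(SCc3ccccc3Br)nc2n1`: 5630 nM

Only compound 2 and compound 3 give numbers, and these lie within the scatter of each other: a 1.3-fold higher number from compound 2 to compound 3 (0.10 log units; within the scatter). Next is compound 4 `Cc1ccc(CSc2nc3nc(C)cc(Nc4cc(-c5ccccc5)[nH]n4)n3n2)cc1`, with 4-methylphenyl in place of 2-bromophenyl on a saturated chain carbon bound to a sulfur.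

Going by the values given here, three measured steps bear on this change, all at the same place. Two start from the cyclohexyl of compound 1 and are beyond the scatter: an at least 11-fold lower number from compound 1 to compound 2 (1.05 log units; beyond the scatter) and an at least 8.8-fold lower number from compound 1 to compound 3 (0.94 log units; beyond the scatter). The third, the exchange of benzoyl for 2-bromophenyl, stayed within the scatter, as shown above. Compound 4 keeps a six-membered aromatic ring of carbon only at this place, so it resembles compound 3 more than compound 1. However, no measured step compares two substituted phenyl groups, so the 4-methylphenyl exchange itself remains untested, and the range is kept wide.

In this assay, the expected change is none beyond the scatter: a 1.1-fold higher number from compound 3 to compound 4 (0.03 log units; within the scatter). The estimate for compound 4 is 6000 nM, with an expected range of 2200 nM to 18000 nM.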

Compound 4, half-maximal inhibitory concentration: 7310 nM
Estimate against measurement, compound 4: 1.2-fold (0.09 log units) below; measured number inside the range.
By their numbers in this assay, from the lowest: compounds 2, 3 and 4 (each within the scatter of the next). At a limit, above all of these: compound 1.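

In this assay, going by these compounds alone, this is the first comparison of two substituted phenyl groups at this position, on a saturated chain carbon bound to a sulfur, and it gives a 1.3-fold higher number from compound 3 to compound 4 (0.11 log units; within the scatter), so exchanging 2-bromophenyl for 4-methylphenyl moves the number no further than the scatter. Within the data shown here, the comparison with benzoyl gives a 1.6-fold higher number from compound 2 to compound 4 (0.22 log units; within the scatter), also within the scatter, while the comparison with cyclohexyl gives an at least 6.8-fold lower number from compound 1 to compound 4 (0.83 log units; beyond the scatter), so all three groups with a six-membered aromatic ring of carbon only stand apart from the cyclohexyl of compound 1, with no compound going against this among the four. Compound 1 gives a limit of the assay and not a number, so the full size of that step stays unknown: the limit of > 50000 nM in this assay, at which 1 of the 4 values shown sits.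

Whether a plain phenyl at this position would stay with compound 2, compound 3 and compound 4 is open, as the ring here always carries a substituent or a carbonyl. Also open, going by these compounds, is whether an amine, a carboxylic acid or a longer chain at this position would shift the number beyond the scatter in either direction.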